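Purine-to-pyrimidine swap on the acetal carbon, MCF7 series

The source may report more compounds than this note shows. Statements on the series, on what has been measured and on what is new or still open speak of the compounds shown alone.

Compound 1 `COC(CN(c1ccccc1CO)S(=O)(=O)c1ccc([N+](=O)[O-])cc1)n1cnc2c(Cl)ncnc21` is the reference point of this set. Among the measured compounds shown here, in a functional assay on MCF7 cells (Homo sapiens) for antiproliferative activity (a higher number here means a weaker inhibitor, a lower number a stronger inhibitor), compound 1 gives 18700 nM, and it is the only compound here with a single number. Compound 3 `COC(CN(c1ccccc1CO)S(=O)(=O)c1ccccc1[N+](=O)[O-])n1cnc2c(Cl)ncnc21` has two entries in this assay, 11300 nM; 3250 nM (2 entries), both lying not far from compound 1 (the several entries of compound 3 in this assay, 11300 nM; 3250 nM (2 entries)). Compound 2 `O=[N+]([O-])c1ccc(S(=O)(=O)N2CC(n3cnc4ncnc(O)c43)OCc3ccccc32)cc1` reaches only a limit in this assay, reported as > 100000 nM (the limit of > 100000 nM in this assay, at which 1 of the 3 values shown sits). Compound 4 `COC(CN(c1ccccc1CO)S(=O)(=O)c1ccc([N+](=O)[O-])cc1)n1c(=O)cc[nH]c1=O` is not yet measured; it differs from compound 1 in one place: a group of 8 heavy atoms (4 carbon, 2 nitrogen, 2 oxygen; one six-membered aromatic ring with 2 hetero atoms) in place of a group of 10 heavy atoms (5 carbon, 4 nitrogen, 1 chlorine; one five-membered aromatic ring with 2 hetero atoms, one six-membered aromatic ring with 2 hetero atoms), on a saturated chain carbon bound to an oxygen on a saturated carbon and a saturated chain carbon. For the measured compounds named here, no measured pair traces this change, so no step size is known. Among the measured compounds, compound 2, whose core lacks the chlorine carried by compound 1 and compound 3, is the one at the limit. On that basis the step of a 3.2-fold higher number from compound 1 to compound 4 (0.51 log units; beyond the scatter) is expected to go beyond the scatter toward a weaker inhibitor. Compound 4 is estimated at 60000 nM, with a range from 15000 nM to 200000 nM, and a real chance that only a limit is recorded.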

Compound 4, half-maximal inhibitory concentration: 55200 nM
Beside the measured number, compound 4's estimate is 1.1-fold (0.04 log units) above it; the measured number falls inside the stated range.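

Among the compounds shown here, this is the first readable step at the saturated chain carbon bound to an oxygen on a saturated carbon and a saturated chain carbon: in this assay, the group of 8 heavy atoms in place of the group of 10 heavy atoms gives a 3.0-fold higher number from compound 1 to compound 4 (0.47 log units; beyond the scatter). The exchange removes the chlorine and the five-membered aromatic ring, yet compound 4 still gives a number and not a limit, so neither is required for a number to be recorded. The step is modest, and repeat entries of a close analogue show how far values can spread in this assay: the several entries of compound 3 in this assay, 11300 nM; 3250 nM (2 entries)

For the compounds shown here, the single step does not separate the loss of the chlorine from the loss of the five-membered aromatic ring. As far as these compounds go, whether an amine in place of the chlorine would retain the number of compound 1 also remains open.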